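A few compounds are considered here, and "the series" means these few. Any claim that something is new, unique, unknown or untested is made for them only; others in the source may bear on it.

Compound 1 `CNc1nncc2cncn12` and compound 2 `CNc1nncc2c(C)ncn12` share one core; compound 3 `Cc1nc(C)n2c(Nc3cc[nH]n3)nccc12` and compound 4 `Cc1ncn2c(Nc3cc[nH]n3)nccc12` share another, and the difference between the two cores is not broken down here. In a functional assay for inhibition, with Homo sapiens as the target (a lower number here means a stronger inhibitor, a higher number a weaker inhibitor), compound 1 reaches only a limit, > 48000 nM. Compound 2 likewise gives only a limit in this assay, > 48000 nM. The step that the two limits leave unreadable from compound 2 to compound 1 cannot be sized, since it rests on (the limit of > 48000 nM in this assay, at which 2 of the 3 values shown sit). Going by the values given here, compound 3 is the one compound with a number in this assay, 53000 nM. The change hydrogen in place of methyl on an aromatic carbon is the same kind of change as hydrogen in place of methyl on an aromatic carbon, though the place differs: in compound 4 it lies between two ring nitrogen atoms, two ring bonds from the ring atom that bears a methyl group, whereas in compound 1 it lies next to the ring nitrogen, two ring bonds from the ring nitrogen. With the measured step unreadable, compound 4 is expected to move little, an estimated 1.0-fold higher number from compound 3 to compound 4 (0.02 log units; within the scatter). Compound 4 is thus estimated at 55000 nM.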

Compound 4, half-maximal inhibitory concentration: 57000 nM
Estimate against measurement, compound 4: 1.0-fold (0.02 log units) below; low and high end bracket the measured number.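

In this assay, hydrogen in place of methyl on an aromatic carbon gives a 1.1-fold higher number from compound 3 to compound 4 (0.03 log units; within the scatter), so the two compounds cannot be told apart on this core. This reading covers one pair at one place, between two ring nitrogen atoms, and no rule for the series follows from it. The same kind of change on the core of compound 1 cannot be read, so whether the result carries from one core to the other stays unknown, the step from compound 2 to compound 1 resting on a limit: the limit of > 48000 nM in this assay, at which 2 of the 4 values shown sit.

Still open, as far as these compounds go, is whether an amine, a carboxylic acid or a longer chain on this aromatic carbon would give a step beyond the scatter on either core. The compounds shown also leave open what the remaining methyl group contributes on the core of compound 4.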